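The compounds below may be only part of what the source reports. "The series", "measured", "known", "first", "only" and "open" are said of these compounds alone.

Working notes on the series. Three compounds have been run in a functional assay on HEK293 cells for antagonist activity at Orexin receptor type 2 (Homo sapiens), read by FLIPR and calcium flux; on this read-out higher numbers stand for higher potency (the scale is a negative logarithm) and lower numbers for lower potency. Compound 1 `Cc1ccc(-c2ncccn2)c(C(=O)N2CC3(CC3)C[C@H]2CNc2ccc(C(F)(F)F)cn2)n1` gives 7.5 in this assay. Compound 3 `O=C(c1cc(Cl)ccc1-c1ncccn1)N1CC2(CC2)C[C@H]1CNc1ccc(C(F)(F)F)cn1` gives 7.2, and compound 2 `O=C(c1cc(Cl)ccc1-c1ncccn1)N1CC2(CC2)C[C@H]1CNc1cc(C(F)(F)F)ccn1` gives 7.1. Compound 1 carries the highest of the three numbers, but its gap to compound 3 is within the scatter; only its gap to compound 2 lies beyond it.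

Compounds 3 and 2 differ in one place: 4-(trifluoromethyl)pyridin-2-yl in place of 5-(trifluoromethyl)pyridin-2-yl on an amine nitrogen. The step is a number 0.10 log units lower from compound 3 to compound 2 (within the scatter), so on this pair the swap left the read-out essentially unchanged.

Compound 4 `Cc1ccc(-c2ncccn2)c(C(=O)N2CC3(CC3)C[C@H]2CNc2cc(C(F)(F)F)ccn2)n1` has not yet been measured. It differs from compound 1 by the same change, at the same place: 4-(trifluoromethyl)pyridin-2-yl in place of 5-(trifluoromethyl)pyridin-2-yl on an amine nitrogen. The cores of compound 1 and compound 3 differ, but that difference is not broken down here, so the swap has been seen once on the core of compound 3 and not yet on the core of compound 1.

Among the compounds with values here, the expected step from compound 1 to compound 4 in this assay is a number 0.10 log units lower from compound 1 to compound 4 (within the scatter), resting on a number 0.10 log units lower from compound 3 to compound 2 (within the scatter) as the one observed instance of this change. For compound 4 the estimate in this assay is 7.4, with a plausible range from 7 to 7.8, the width reflecting that the change has been seen only once and on a different core.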

Compound 4, negative logarithm of the antagonist equilibrium constant: 8.1
Compound 4: the middle estimate sits 0.70 log units below what was measured; measured number above the stated range.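

In this assay, 4-(trifluoromethyl)pyridin-2-yl in place of 5-(trifluoromethyl)pyridin-2-yl on an amine nitrogen gives a number 0.60 log units higher from compound 1 to compound 4 (beyond the scatter). Set beside the earlier instance, the same change does not give the same step on the two cores: the same change on two cores in this assay, a number 0.10 log units lower (within the scatter) from compound 3 to compound 2 and a number 0.60 log units higher (beyond the scatter) from compound 1 to compound 4, 0.70 log units apart, beyond the scatter of two such steps

So in this series a step read on one core did not carry over to the other, and the result of this change depends on the core it is made on; what the notes do not show is which part of the cores accounts for the disagreement, and one instance per core gives no rule for any further core.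

As far as these compounds go, the two cores differ in more than one feature, so it remains open which of those features goes with the larger step seen on the core of compound 1. Also open, from the compounds shown here alone, is whether a nitrile or a methoxy group in place of the trifluoromethyl on the pyridine would follow the same course on each core.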